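The compounds below may be only part of what the source reports. "The series", "measured", "known", "first", "only" and "open" are said of these compounds alone.

Working notes on the series, read in a functional assay on MCF7 cells (Homo sapiens) for inhibition, read by CCK-8 assay, with a stated time of 48 h; on this read-out lower numbers stand for stronger inhibition of growth and higher numbers for weaker inhibition of growth. Compound 1 `Cc1ccccc1Nc1nc(NCc2ccco2)ncc1Cl` gives > 100000 nM, which is a limit of the assay and not a number. Compound 2 `Cc1ccccc1Nc1nc(Nc2ccc(N3CCCCC3)cc2)ncc1Cl` gives > 100000 nM, also a limit. Among the compounds with values here, compound 3 `CN1CCN(c2ccc(Nc3ncc(Cl)c(NCc4ccc(C(F)(F)F)cc4)n3)nc2)CC1` gives 28400 nM, the only true number so far. Compound 4 `Cc1cccc(Nc2nc(Nc3ccc(N4CCN(C)CC4)cn3)ncc2Cl)c1` has not yet been measured. It carries 3-methylphenyl in place of 4-(trifluoromethyl)benzyl on a nitrogen on an aromatic ring. Within the data shown here, no step between measured compounds is available to size this change, so the expectation rests on compound 3 at 28400 nM, and no shift beyond the scatter is expected. The expected step of a 1.2-fold higher number from compound 3 to compound 4 (0.09 log units; within the scatter) is an estimate and remains uncertain. Compound 4 is estimated at 35000 nM, with an expected range of 8000 nM to 100000 nM.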

Compound 4, concentration for 50% growth inhibition: 7160 nM
Beside the measured number, compound 4's estimate is 4.9-fold (0.69 log units) above it; the measured number lies below the stated range.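

In this assay, 3-methylphenyl in place of 4-(trifluoromethyl)benzyl on a nitrogen on an aromatic ring gives a 4.0-fold lower number from compound 3 to compound 4 (0.60 log units; beyond the scatter), so the group at this position can shift growth inhibition beyond the scatter. Compound 1 and compound 2 could not show this, because their readings are limits and not numbers: the limit of > 100000 nM in this assay, at which 2 of the 4 values shown sit.

Within the data shown here, the single step changes the ring's substituent and its link to the nitrogen together, so it cannot separate the two. Going by these compounds, how an aliphatic amine or a carboxylic acid on this nitrogen would read remains open.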